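Swapping the Aryl Group on the Amine-Linked Carbon

The compounds below may be only part of what the source reports. "The series", "measured", "known", "first", "only" and "open" are said of these compounds alone.

Compound 1, `O=S(=O)(NCCCCNCc1ccc(Br)cc1)c1cc(C(F)(F)F)cc(C(F)(F)F)c1`, gives 2100 nM in a functional assay on A2780 cells (Homo sapiens) for inhibition, read by MTT assay, with a stated time of 72 h; a higher number here means a weaker inhibitor of growth, a lower number a stronger inhibitor of growth.
Compound 2, `O=S(=O)(NCCCNCc1ccc(Cl)c(Cl)c1)c1cc(C(F)(F)F)cc(C(F)(F)F)c1`, gives 1500 nM in this assay.
Compound 3, `O=S(=O)(NCCCNCc1cccc2ccccc12)c1cc(C(F)(F)F)cc(C(F)(F)F)c1`, gives 3100 nM in this assay.

Compound 3 carries the highest number of the three. Its gap to compound 1 lies within the scatter, so those two cannot be told apart, whereas a 2.1-fold higher number from compound 2 to compound 3 (0.32 log units; beyond the scatter) is a modest step that does stand outside the scatter. All three share the same sulfonamide core and differ only in the aromatic group attached to the saturated chain carbon bound to the amine nitrogen.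

Compound 4, `COc1ccc(CNCCCNS(=O)(=O)c2cc(C(F)(F)F)cc(C(F)(F)F)c2)cc1`, differs from compound 3 at exactly that spot: 4-methoxyphenyl in place of naphthalen-1-yl on a saturated chain carbon bound to an amine nitrogen. Among the compounds with values here, two measured steps bear on a change here. a 1.4-fold lower number from compound 1 to compound 2 (0.15 log units; within the scatter) shows that trading one substituted phenyl for another barely moved the number, while a 2.1-fold higher number from compound 2 to compound 3 (0.32 log units; beyond the scatter) shows that moving to the two-ring naphthalen-1-yl raised it modestly. Going back to a single substituted ring in compound 4 is therefore expected to undo part of that rise, giving a modestly lower number, though a 4-methoxyphenyl has no measured precedent among these compounds, so the expected step of a 1.3-fold lower number from compound 3 to compound 4 (0.13 log units; within the scatter) is set small.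

Compound 4 is estimated at 2300 nM in this assay, with a likely range from 1100 nM to 5000 nM.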

Compound 4, concentration for 50% growth inhibition: 1700 nM
Estimate against measurement, compound 4: 1.4-fold (0.13 log units) above, and the stated range covers the measured number.
By their numbers in this assay, from the lowest: compounds 2, 4, 1 and 3 (each within the scatter of the next, the first and the last beyond it).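

In this assay the change from naphthalen-1-yl to 4-methoxyphenyl (a 1.8-fold lower number from compound 3 to compound 4 (0.26 log units; within the scatter)) cannot be told apart from no change at all. The same holds against the two halogen-bearing rings (a 1.1-fold higher number from compound 2 to compound 4 (0.05 log units; within the scatter); a 1.2-fold lower number from compound 1 to compound 4 (0.09 log units; within the scatter)), so a single ring with a methoxy group, which brings in oxygen and one hydrogen-bond acceptor, gives a number that cannot be separated from theirs. Compound 4 therefore lies within the scatter of both compound 2 and compound 3, even though those two lie beyond the scatter of each other, and the only gap beyond the scatter among these compounds remains a modest one.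

Nothing available gives a reason for any of these numbers. On these data alone, it remains open whether a group of a different kind on the saturated chain carbon bound to the amine nitrogen, such as an unsubstituted phenyl, a pyridine ring or a phenyl ring carrying a carboxylic acid, would shift the number well beyond the scatter, and whether the same small spread would hold on a longer chain.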